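Swapping hydroxy for amino on a growth inhibitor

The compounds below may be only part of what the source reports. "The series", "measured", "known", "first", "only" and "open" are said of these compounds alone.

In a functional assay on NCI-H417 cells (Homo sapiens) for cytotoxicity, read by trypan blue exclusion, with a stated time of 96 h (on this read-out lower numbers stand for stronger inhibition of growth and higher numbers for weaker inhibition of growth), compound 1 (`COc1ccc(NS(=O)(=O)/C=C/c2c(OC)cc(OC)cc2OC)cc1`) gives 50 nM. Going by the values given here, compound 2 (`COc1cc(OC)c(/C=C/S(=O)(=O)Nc2ccc(OC)c(O)c2)c(OC)c1`) gives 10 nM, the lowest of the two numbers measured so far and so the stronger inhibition of growth. Compound 3 (`COc1cc(OC)c(/C=C/S(=O)(=O)Nc2ccc(OC)c(N)c2)c(OC)c1`) has amino in place of hydroxy on an aromatic carbon, ortho to a methoxy group: amino in place of hydroxy on an aromatic carbon. Among the compounds with values here, no measured step covers this exact swap. The only one that bears on it is a 5.0-fold lower number from compound 1 to compound 2 (0.70 log units; beyond the scatter), a modest step beyond the scatter, made by hydroxy in place of hydrogen on an aromatic carbon. Amino matches hydroxy in the counted hydrogen-bond donors and acceptors, so much of that gain is expected to remain. In this assay, the expected change is small and within the scatter: a 1.5-fold higher number from compound 2 to compound 3 (0.18 log units; within the scatter). Compound 3 is estimated at 15 nM, with an expected range of 4 nM to 50 nM.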

Compound 3, concentration for 50% growth inhibition: 4 nM
The estimate for compound 3 lay 3.8-fold (0.57 log units) above the measured number; the measured number falls inside the stated range.
By their numbers in this assay, from the lowest: compound 3; then compound 2; then compound 1.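

In this assay, this position tells amino and hydroxy apart, with a 2.5-fold lower number from compound 2 to compound 3 (0.40 log units; beyond the scatter), even though each group counts as one hydrogen-bond donor and one hydrogen-bond acceptor. Starting from hydrogen at this position, amino gives a 13-fold lower number from compound 1 to compound 3 (1.10 log units; beyond the scatter), a larger step than hydroxy gives with a 5.0-fold lower number from compound 1 to compound 2 (0.70 log units; beyond the scatter), so equal donor and acceptor counts do not make the two groups equal here. Nothing available accounts for the difference between them.

From the compounds shown here alone, it remains open whether a methylamino or an acetylamino group at the same position would keep the low number of compound 3 or lose it, which would show how far the amino group can be changed. Going by these compounds, it is also open whether the same order of the three compounds holds in other cell types.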